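Adding a Second Piperidinyl to an Acylguanidine Sodium/Hydrogen Exchanger Inhibitor

This account rests on a few compounds, and the source may have more. Where it says the series, first, only, none or still open, it means among the compounds named here.

Measured compounds:
- compound 1, `Cc1cc(C)c(S(C)(=O)=O)cc1C(=O)N=C(N)N`, 11 nM
- compound 2, `Cc1cc(N2CCCCC2)c(S(C)(=O)=O)cc1C(=O)N=C(N)N`, 21 nM
- compound 3, `Cc1cc(N2CCCC(O)C2)c(S(C)(=O)=O)cc1C(=O)N=C(N)N`, 30 nM

All three compounds share one core and were tested in a functional assay for inhibition of sodium/hydrogen exchanger (Oryctolagus cuniculus); on this read-out lower numbers stand for stronger inhibition and higher numbers for weaker inhibition. Among the three numbers, compound 2 gives the second highest; its nearest neighbour is compound 3, whose value differs by a 1.4-fold higher number from compound 2 to compound 3 (0.15 log units; within the scatter), and the furthest is compound 1, the step from which is a 1.9-fold higher number from compound 1 to compound 2 (0.28 log units; within the scatter). Both gaps lie within the scatter, so no order among these three can be claimed.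

Compound 4, `CS(=O)(=O)c1cc(C(=O)N=C(N)N)c(N2CCCCC2)cc1N1CCCCC1`, has not yet been measured. It differs from compound 2 by piperidin-1-yl in place of methyl on an aromatic carbon. For the measured compounds named here, the only measured step of the same kind is the one from compound 1 to compound 2, where a piperidin-1-yl also replaced a methyl on an aromatic carbon and gave a 1.9-fold higher number from compound 1 to compound 2 (0.28 log units; within the scatter), a change within the scatter. The related step of a 2.7-fold higher number from compound 1 to compound 3 (0.44 log units; beyond the scatter) was modest. On this basis only a small shift toward a higher number, if any beyond the scatter, is expected for compound 4: the estimate is 35 nM, with a range of 15 nM to 90 nM, which corresponds to an expected step of a 1.7-fold higher number from compound 2 to compound 4 (0.22 log units; within the scatter).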

Compound 4, half-maximal inhibitory concentration: 1000 nM
The estimate for compound 4 lay 29-fold (1.46 log units) below the measured number, outside the stated range (above it).
By their numbers in this assay, from the lowest: compounds 1, 2 and 3 (each within the scatter of the next, the first and the last beyond it); then compound 4.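

In this assay, the same exchange of methyl for piperidin-1-yl that earlier gave only a 1.9-fold higher number from compound 1 to compound 2 (0.28 log units; within the scatter) now gives a 48-fold higher number from compound 2 to compound 4 (1.68 log units; beyond the scatter), so the effect of this change depends strongly on which methyl is replaced. The methyl that matters here sits on the aromatic carbon ortho to a group of 6 heavy atoms, para to a methylsulfonyl group and meta to a piperidin-1-yl group, and among the compounds shown, only a change at this carbon moves the number by a large step. Nothing available explains why this carbon tolerates the exchange so much less well than the other one.

The compounds shown leave open whether the piperidin-1-yl group in particular produces this loss, or whether other replacements for methyl at this carbon, such as an ethyl or a dimethylamino group, would do the same. They also leave open whether the size of the step depends on the piperidin-1-yl group that compound 2 already carries and compound 4 keeps.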